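Removing One Methoxy from a Weak CDK8 Urea

A few compounds are considered here, and "the series" means these few. Any claim that something is new, unique, unknown or untested is made for them only; others in the source may bear on it.

Measured compounds:
- Compound 1, `CNc1nccc(N2CC[C@H](NC(=O)Nc3cc(OC)cc(OC)c3)C2)n1`: 5010 nM
- Compound 2, `O=C(Nc1ccc(Cl)c(C(F)(F)F)c1)N[C@@H]1CCN(c2ccc3nncn3n2)C1`: 166 nM

Both compounds were tested in an assay on a protein complex for displacement of a labelled ligand from CDK8/Cyclin C (Homo sapiens), read by TR-FRET, with a stated time of 1 h; on this read-out higher numbers stand for weaker inhibition and lower numbers for stronger inhibition. Compound 1 gives 5010 nM, the highest of the two numbers and therefore the weaker of the pair. Compound 2 gives 166 nM, a much lower number; the gap between these two lies well beyond the scatter of repeated measurements. The two compounds differ in several places at once, so nothing can be said about which part of the structure is responsible.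

The new compound is compound 3, `CNc1nccc(N2CC[C@H](NC(=O)Nc3cccc(OC)c3)C2)n1`. It differs from compound 1 in one place only: hydrogen in place of methoxy on an aromatic carbon. Within the data shown here, no pair of measured compounds shows this exact change, so there is no measured step to lean on. Such a small trim of the outer ring is expected to give a step of modest size, in either direction or none beyond the scatter; the step from a 1.2-fold higher number from compound 1 to compound 3 (0.08 log units; within the scatter) is the expected outcome. Compound 3 is estimated at 6000 nM, with a range from 2000 nM to 18000 nM.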

Compound 3, half-maximal inhibitory concentration in the CDK8/Cyclin C assay: 3620 nM
For compound 3 the middle estimate is 1.7-fold (0.22 log units) above the measured one, within the range that was stated.
By their numbers in the CDK8/Cyclin C assay, from the lowest: compound 2; then compounds 3 and 1 (each within the scatter of the next).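

In the CDK8/Cyclin C assay, compound 1 gives 5010 nM and compound 3 gives 3620 nM; trading one methoxy for hydrogen on the aromatic carbon of the outer ring gives a 1.4-fold lower number from compound 1 to compound 3 (0.14 log units; within the scatter), so this methoxy can go without any change that stands out from ordinary repeat variation. It also means that the second methoxy of compound 1 adds nothing readable to the binding signal, a point that the earlier comparison, with its several differences at once, could not show. In a physicochemical assay for solubility, measured as kinetic solubility (a higher number here means a more soluble compound, a lower number a less soluble compound), compound 1 gives 79400 nM and compound 3 gives 116000 nM, and the same swap gives a 1.5-fold higher number from compound 1 to compound 3 (0.16 log units; within the scatter), so the two compounds cannot be told apart on this measure either, and the data give no explanation for either result.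

The compounds shown leave open whether the methoxy that remains on the ring matters, since it stays in place in both compound 1 and compound 3. They also leave open whether a different group on this same aromatic carbon, such as an amine, a chlorine atom or a longer chain like ethoxy, would shift the number in the CDK8/Cyclin C assay by more than this simple removal did.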